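The source may report more compounds than this note shows. Statements on the series, on what has been measured and on what is new or still open speak of the compounds shown alone.

Compound 1 `O=C(/C=C/c1cccc(NC(=O)c2ccccc2Cl)c1)c1nc2ccccc2[nH]1`: 3690 nM in a functional assay on 143B cells (Homo sapiens) for antiproliferative activity, read by MTT assay, with a stated time of 48 h; a higher number here means a weaker inhibitor, a lower number a stronger inhibitor
Compound 2 `O=C(/C=C/c1cccc(NC(=O)c2ccccc2Br)c1)c1nc2ccccc2[nH]1`: 6050 nM in this assay

Compound 1 has the lowest of the two numbers; its nearest neighbour is compound 2, at a 1.6-fold higher number from compound 1 to compound 2 (0.21 log units; within the scatter). Compound 3 `COc1cccc(C(=O)Nc2cccc(/C=C/C(=O)c3nc4ccccc4[nH]3)c2)c1` differs from compound 1 by 3-methoxyphenyl in place of 2-chlorophenyl on a carbonyl carbon. Within the data shown here, the single measured step, bromo in place of chloro, is a different change and does not bear on this one, so no measured step supports or contradicts an expectation here. Compound 3 is therefore expected to show no step beyond the scatter, estimated at a 1.2-fold higher number from compound 1 to compound 3 (0.09 log units; within the scatter). The estimate for compound 3 is 4500 nM, with a range from 1500 nM to 13000 nM.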

Compound 3, half-maximal inhibitory concentration: 4610 nM
For compound 3 the middle estimate is 1.0-fold (0.01 log units) below the measured one, and the stated range covers the measured number.
By their numbers in this assay, from the lowest: compounds 1, 3 and 2 (each within the scatter of the next).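

In this assay the step is a 1.2-fold higher number from compound 1 to compound 3 (0.10 log units; within the scatter) where 3-methoxyphenyl replaces 2-chlorophenyl, and a 1.3-fold lower number from compound 2 to compound 3 (0.12 log units; within the scatter) where the group replaced is 2-bromophenyl. The earlier compounds shown here showed only one halogen exchanged for another, whereas these steps show that a non-halogen group here also stays within the scatter. No evidence given here bears on this result.

Going by these compounds, whether an amine or a carboxylic acid on this phenyl ring would also stay within the scatter remains open.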